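This account rests on a few compounds, and the source may have more. Where it says the series, first, only, none or still open, it means among the compounds named here.

Of the compounds shown here, three that share one core have been tested in a functional assay on HeLa cells (Homo sapiens) for antiproliferative activity, with a stated time of 5 days; on this read-out higher numbers stand for weaker inhibition and lower numbers for stronger inhibition. Compound 1 `O=C1C=CC2(C=C1)OCC(=O)N2c1nc(-c2ccc3ccccc3c2Br)nn1-c1ccccc1` gives 290 nM. Compound 2 `O=C1C=CC2(C=C1)OCC(=O)N2c1nc(-c2ccc(F)c3ccccc23)nn1-c1ccccc1` gives 200 nM, and compound 3 `O=C1C=CC2(C=C1)OCC(=O)N2c1nc(-c2ccc3ncccc3c2)nn1-c1ccccc1` gives 110 nM. Among these three, compound 3 carries the lowest number: the step of a 2.6-fold lower number from compound 1 to compound 3 (0.42 log units; beyond the scatter) lies beyond the scatter, whereas the steps of a 1.5-fold lower number from compound 1 to compound 2 (0.16 log units; within the scatter) and a 1.8-fold lower number from compound 2 to compound 3 (0.26 log units; within the scatter) do not, so compound 3 and compound 2 cannot be told apart on these numbers.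

Compound 4 `O=C1C=CC2(C=C1)OCC(=O)N2c1nc(-c2cccc(Cl)c2)nn1-c1ccccc1` has not yet been measured in this assay. It differs from compound 3 in one place: 3-chlorophenyl in place of quinolin-6-yl on an aromatic carbon. Among the measured compounds shown here, the measured steps that touch this position, a 2.6-fold lower number from compound 1 to compound 3 (0.42 log units; beyond the scatter) and a 1.8-fold lower number from compound 2 to compound 3 (0.26 log units; within the scatter), each exchange one two-ring group for another and stayed small to modest; no measured step drops to a single ring, as this change does. Since all three two-ring groups gave numbers close together, the estimated step of a 3.6-fold higher number from compound 3 to compound 4 (0.56 log units; beyond the scatter) is a modest rise in number, with wide uncertainty. Compound 4 is therefore expected to give 400 nM in this assay, with a likely range from 150 nM to 1100 nM.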

Compound 4, half-maximal inhibitory concentration: 45.3 nM
The estimate for compound 4 lay 8.8-fold (0.95 log units) above the measured number; measured number outside the range, below it.
By their numbers in this assay, from the lowest: compound 4; then compounds 3, 2 and 1 (each within the scatter of the next, the first and the last beyond it).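

At this position, the aromatic carbon between two ring nitrogen atoms, a two-ring group is not required for a low number in this assay: the single ring of 3-chlorophenyl replaces quinolin-6-yl with (a 2.4-fold lower number from compound 3 to compound 4 (0.39 log units; beyond the scatter)). The same single ring also improves on the two halogenated naphthalene groups, with (a 4.4-fold lower number from compound 2 to compound 4 (0.64 log units; beyond the scatter)) and (a 6.4-fold lower number from compound 1 to compound 4 (0.81 log units; beyond the scatter)), so compound 4 has the lowest number of the four and a smaller group here did not cost activity. No measurement is available that explains this result.

On these data alone, it remains open whether the chlorine contributes to the low number, which plain phenyl or 4-chlorophenyl at this carbon could test. Also open, as far as these compounds go, is how a ring carrying a methoxy group or an amine, or a non-aromatic cyclohexyl group, would behave here.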